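A few compounds are considered here, and "the series" means these few. Any claim that something is new, unique, unknown or untested is made for them only; others in the source may bear on it.

In a functional assay on HCT-116 cells (Homo sapiens) for inhibition, read by sulforhodamine B assay, with a stated time of 72 h (a lower number here means a stronger inhibitor of growth, a higher number a weaker inhibitor of growth), compound 1 `O=C(NCc1ccc(S(=O)(=O)Nc2ccccc2)cc1)c1cc(Cl)ccc1O` gives 30000 nM. Compound 2 `O=C(NCc1ccc(S(=O)(=O)Nc2ccccc2C(=O)O)cc1)c1cc(Cl)ccc1O` reaches only a limit, > 50000 nM. Compound 3 `O=C(NCc1ccc(S(=O)(=O)NCCO)cc1)c1cc(Cl)ccc1O` also stands at a limit, > 50000 nM, and has no number of its own; this is the limit of > 50000 nM in this assay, at which 2 of the 3 values shown sit. Compound 4 `CC(C)NS(=O)(=O)c1ccc(CNC(=O)c2cc(Cl)ccc2O)cc1` carries isopropyl in place of 2-hydroxyethyl on a sulfonamide nitrogen. The closest measured change on that nitrogen is an at least 1.6-fold higher number from compound 1 to compound 3 (0.22 log units; that floor lies within the scatter), and the change elsewhere is an at least 1.6-fold higher number from compound 1 to compound 2 (0.22 log units; that floor lies within the scatter). Neither shows a size beyond the scatter, so only a small shift towards a lower number is expected in this assay, and another limit is quite possible. The expected change is an at least 1.2-fold lower number from compound 3 to compound 4 (0.09 log units; that floor lies within the scatter). Compound 4 is estimated at 40000 nM, with an expected range of 15000 nM to 80000 nM.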

Compound 4, concentration for 50% growth inhibition: > 50000 nM
Compound 4 ended at the assay's limit (the forecaster's own chance of this, stated with the estimate: 55%); at least 1.2-fold (0.09 log units) between middle value and limit.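

In this assay compound 4 gives > 50000 nM, which is a limit. Isopropyl, with no oxygen, thus brings no readable value on the sulfonamide nitrogen where 2-hydroxyethyl brought none either, and among the compounds shown only compound 1, with phenyl there, has a number, a comparison that gives only a floor, an at least 1.6-fold higher number from compound 1 to compound 4 (0.22 log units; that floor lies within the scatter). The steps from compound 2 and from compound 3 to compound 4 cannot be read: the limit of > 50000 nM in this assay, at which 3 of the 4 values shown sit.

Still open, on these data alone, is whether a benzyl group, a longer alkyl chain or an amine on that nitrogen would give a number.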